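The compounds below may be only part of what the source reports. "The series", "measured", "known", "first", "only" and "open" are said of these compounds alone.

Compound 2, with the structure `O=C1Nc2ccc(Br)cc2/C1=N/NC(=S)N/N=C/c1ccccc1Br`, is the reference point for this step. In a functional assay on HeLa cells (Homo sapiens) for inhibition, read by MTT assay (on this read-out lower numbers stand for stronger inhibition and higher numbers for weaker inhibition), compound 2 gives > 50000 nM, which is a limit of the assay and not a measured number. Going by the values given here, compound 1, with the structure `O=C1Nc2ccc(Br)cc2/C1=N/NC(=S)N/N=C/c1c(Cl)cccc1Cl`, is the only compound of this set with a numerical value: in this assay compound 1 gives 3530 nM. Among the compounds with values here, the single measured step, an at least 14-fold higher number from compound 1 to compound 2 (1.15 log units; beyond the scatter), shows that changing the aryl group attached to the carbon with a double bond to nitrogen can move the read-out by a large amount, and because of the limit of > 50000 nM in this assay, at which 1 of the 2 values shown sits, the true size of that step is unknown. Compound 3, with the structure `O=C1Nc2ccc(Br)cc2/C1=N/NC(=S)N/N=C/c1ccc(Br)cc1`, carries the change (4-bromophenyl in place of 2-bromophenyl on a carbon with a double bond to nitrogen). Within the data shown here, no measured step touches this particular change, so the direction of the step in this assay cannot be taken from the data; what the step from compound 1 to compound 2 does show is that this position is sensitive. Compound 3 is expected to give 30000 nM in this assay, within a wide range from 5000 nM to 100000 nM. The step this estimate means is an at least 1.6-fold lower number from compound 2 to compound 3 (0.22 log units; that floor lies within the scatter), which is an expectation only.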

Compound 3, half-maximal inhibitory concentration: 4680 nM
Estimate against measurement, compound 3: 6.4-fold (0.81 log units) above, outside the stated range (below it).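

Swapping 2-bromophenyl for 4-bromophenyl, with the same atoms joined differently, gives an at least 10-fold lower number from compound 2 to compound 3 (1.02 log units; beyond the scatter) in this assay, so at this position the placing of the bromine on the phenyl ring matters by itself, and not only the kind of aryl group. Replacing 2,6-dichlorophenyl with 4-bromophenyl gives a 1.3-fold higher number from compound 1 to compound 3 (0.12 log units; within the scatter), and of the three aryl groups on the carbon with a double bond to nitrogen, only 2-bromophenyl stands apart. Compound 2 sits at a limit of the assay and not at a number, and the true size of the steps that touch it stays unknown because of that limit: the limit of > 50000 nM in this assay, at which 1 of the 3 values shown sits.

The compounds shown leave open whether the aryl group needs a halogen at all, since an unsubstituted phenyl ring and a phenyl ring carrying an amine, a methoxy group or a carboxylic acid in place of the bromine do not appear among them. They also leave open whether the same steps would appear if the bromine on the shared core were replaced by chlorine or by hydrogen.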